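The compounds below may be only part of what the source reports. "The series", "measured", "known", "first", "only" and "open" are said of these compounds alone.

Measured so far:
- compound 1, `Cc1ccc(S(=O)(=O)N2CCC(Cl)CC2)cc1`: > 100000 nM
- compound 2, `Cc1ccc(S(=O)(=O)N2CCC(Br)CC2)cc1`: > 100000 nM

Both entries are limits of a functional assay on A2780 cells (Homo sapiens) for antiproliferative activity, read by sulforhodamine B assay, with a stated time of 48 h (on this read-out higher numbers stand for weaker inhibition of growth and lower numbers for stronger inhibition of growth), not numbers. Compound 1 is reported only as the limit > 100000 nM. Compound 2 likewise stands only at the limit > 100000 nM in this assay, so its position among the numbers shown is undefined beyond that. For the measured compounds named here, the one step between measured compounds, a step that the two limits leave unreadable from compound 1 to compound 2, is therefore unreadable: bromo in place of chloro on a saturated ring carbon, with both ends sitting at the limit (the limit of > 100000 nM in this assay, at which 2 of the 2 values shown sit).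

Compound 3, `CCCCCCC[C@H]1C[C@H](Br)CCN1S(=O)(=O)c1ccc(C)cc1`, is next. The change from compound 2 is heptyl in place of hydrogen on a saturated ring carbon. Going by the values given here, no measured step bears on this change, since the single step available cannot be sized. The expectation for compound 3 in this assay is thus an estimate of 60000 nM (range 8000 nM to 300000 nM), a step of an at least 1.6-fold lower number from compound 2 to compound 3 (0.22 log units; that floor lies within the scatter) that has no readable step to be set against, with a substantial chance that compound 3 again gives only a limit.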

Compound 3, concentration for 50% growth inhibition: > 100000 nM
Compound 3: a limit, no number; the forecaster's own chance of this, stated with the estimate: 55%; middle value at least 1.6-fold (0.22 log units) away from the limit.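

For the compounds shown here, compound 2 and compound 3 both stand only as limits, so no step between them can be read: the limit of > 100000 nM in this assay, at which 3 of the 3 values shown sit.
The compounds shown leave open whether heptyl in place of hydrogen on a saturated ring carbon, or bromo in place of chloro, changes growth inhibition in this assay at all.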